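Ester side chain carried over to a second core

The compounds below may be only part of what the source reports. "The series", "measured", "known", "first", "only" and "open" are said of these compounds alone.

Compound 1 `CCn1sc(Cl)cc1=O` and compound 2 `COC(=O)CCn1sc(Cl)cc1=O` share one core; compound 3 `CCn1c(=O)c(C)c(Cl)[s+]1[O-]` and compound 4 `COC(=O)CCn1c(=O)c(C)c(Cl)[s+]1[O-]` share another, and the difference between the two cores is not broken down here. In a functional assay on HepG2 cells (Homo sapiens) for inhibition, read by crystal violet staining, with a stated time of 48 h (on this read-out higher numbers stand for weaker inhibition and lower numbers for stronger inhibition), compound 1 gives 12000 nM. Compound 2 gives 24000 nM in this assay. The change between them is methoxycarbonyl in place of hydrogen on a saturated chain carbon, two bonds along the chain from an aromatic nitrogen, and it made a 2.0-fold higher number from compound 1 to compound 2 (0.30 log units; within the scatter). Compound 3 reaches only a limit of this assay, > 100000 nM. Compound 4 carries the same change on the core of compound 3: methoxycarbonyl in place of hydrogen on a saturated chain carbon, two bonds along the chain from an aromatic nitrogen. On the first core this change stayed within the scatter, so the same is expected on the second. Compound 4 is expected to differ from its parent by about a step that the limit leaves unreadable from compound 3 to compound 4. Compound 4 is therefore expected at about 200000 nM, between 50000 nM and 1000000 nM, and most likely reported only as a limit. That expectation rests on (the limit of > 100000 nM in this assay, at which 1 of the 3 values shown sits), which is where compound 3 already stands, together with the small step measured on the first core.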

Compound 4, half-maximal inhibitory concentration: > 100000 nM
Compound 4 ended at the assay's limit; the forecaster's own chance of this, stated with the estimate: 85%; the middle value does not contradict the limit.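

In this assay, compound 3 and compound 4 both stand at a limit and not at a number, so no step between them can be read: the limit of > 100000 nM in this assay, at which 2 of the 4 values shown sit.

The compounds shown leave open whether methoxycarbonyl in place of hydrogen alters the read-out at all on the core of compound 3, as it cannot be sized there in this assay.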